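Swapping an Amine for a Silicon Group

A few compounds are considered here, and "the series" means these few. Any claim that something is new, unique, unknown or untested is made for them only; others in the source may bear on it.

Compound 1 `CC(=O)OC/C1=C/C[C@](C)(CCC=C(C)C)/C=C/[C@@H](OC(=O)C=C(C)C)[C@](C)(O)/C=C/C1=O`: 2950 nM
Compound 2 `CC(C)=CCC[C@]1(C)/C=C/[C@@H](OC(=O)C=C(C)C)[C@](C)(O)/C=C/C(=O)/C(CN(C)C)=C\C1`: 820 nM
Compound 3 `CCN(CC)C/C1=C/C[C@](C)(CCC=C(C)C)/C=C/[C@@H](OC(=O)C=C(C)C)[C@](C)(O)/C=C/C1=O`: 570 nM

These results come from a functional assay on SMMC-7721 cells (Homo sapiens) for antiproliferative activity, read by MTT assay, with a stated time of 48 h; a lower number here means a stronger inhibitor, a higher number a weaker inhibitor. Compound 3, at 570 nM, cannot be separated from compound 2, since the step of a 1.4-fold lower number from compound 2 to compound 3 (0.16 log units; within the scatter) lies within the scatter. Both stand clear of compound 1, which carries an acetoxy group at the same place. The steps of a 3.6-fold lower number from compound 1 to compound 2 (0.56 log units; beyond the scatter) and a 5.2-fold lower number from compound 1 to compound 3 (0.71 log units; beyond the scatter) are modest but beyond the scatter.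

The next compound, compound 4 `CC[Si](CC)(CC)C/C1=C/C[C@](C)(CCC=C(C)C)/C=C/[C@@H](OC(=O)C=C(C)C)[C@](C)(O)/C=C/C1=O`, has not yet been measured. Its change from compound 3 is a group of 7 heavy atoms (6 carbon, 1 silicon; no ring) in place of a group of 5 heavy atoms (4 carbon, 1 nitrogen; no ring), on a saturated chain carbon bound to a double-bonded ring carbon, on a saturated chain carbon bound to a double-bonded ring carbon. Within the data shown here, the nitrogen of the diethylamino group is lost, and no measured compound carries silicon, so no measured step shows this swap directly. Among the measured compounds shown here, the closest guide is that the only measured compound without nitrogen in this group, compound 1, gives 2950 nM. A modest move back towards that number therefore seems likely, meaning a weaker inhibitor, though this rests on very few compounds. The expected step in this assay is a 2.3-fold higher number from compound 3 to compound 4 (0.36 log units; beyond the scatter). For compound 4 the estimated value is 1300 nM, with an expected range of 400 nM to 4000 nM.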

Compound 4, half-maximal inhibitory concentration: 3460 nM
Compound 4: middle estimate off by 2.7-fold (0.43 log units), on the low side, and the stated range covers the measured number.
By their numbers in this assay, from the lowest: compounds 3 and 2 (each within the scatter of the next); then compounds 1 and 4 (each within the scatter of the next).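

In this assay the silicon group loses the whole advantage that the two amines held over the acetoxy group, with a 6.1-fold higher number from compound 3 to compound 4 (0.78 log units; beyond the scatter) and a 4.2-fold higher number from compound 2 to compound 4 (0.63 log units; beyond the scatter) both standing beyond the scatter. The silicon group and the acetoxy group share no atom type apart from carbon, yet a 1.2-fold higher number from compound 1 to compound 4 (0.07 log units; within the scatter) leaves them indistinguishable, so a larger group without nitrogen did not restore the lower number. Among these four compounds, the lower numbers go only with the diethylamino and dimethylamino groups, and no compound here goes against that, although four compounds at a single position make a narrow basis for any pattern.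

Still open, as far as these compounds go, is whether a ring amine such as piperidine or morpholine would keep the advantage of the two open-chain amines, and whether an all-carbon group of the same size would match the silicon group. Nothing available explains why the number rises when the nitrogen is replaced at this position.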